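Morpholine to Pyrrolidine on the Amide of Compound 1

The source may report more compounds than this note shows. Statements on the series, on what has been measured and on what is new or still open speak of the compounds shown alone.

Compound 1 `Cn1c(/C=C2\SC(=O)N(CC(=O)N3CCOCC3)C2=O)nc2ccccc21` was tested in a functional assay on PC-3 cells (Homo sapiens) for inhibition, read by MTT assay, with a stated time of 48 h (on this read-out higher numbers stand for weaker inhibition and lower numbers for stronger inhibition), where compound 1 gives only a limit, > 50000 nM, so its position is known just as a bound. In this assay compound 3 `CC(C)n1c(/C=C2\SC(=O)N(CC(=O)N3CCOCC3)C2=O)nc2ccccc21` also gives only a limit, > 50000 nM. The step that the two limits leave unreadable from compound 1 to compound 3 is therefore unreadable, as both values sit at the limit of > 50000 nM in this assay, at which 2 of the 3 values shown sit. Compound 2 `Cn1c(/C=C2\SC(=O)N(CC(=O)Nc3nc(-c4ccccc4)cs3)C2=O)nc2ccccc21`, which carries a different amide, gives 39900 nM in this assay, a number rather than a bound.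

Compound 4 `Cn1c(/C=C2\SC(=O)N(CC(=O)N3CCCC3)C2=O)nc2ccccc21` differs from compound 1 by pyrrolidin-1-yl in place of morpholin-4-yl on a carbonyl carbon. No measured step follows this change, and the only step among the measured compounds is unreadable, so no direction can be drawn from the numbers shown. The account expects compound 4 to stay close to where compound 1 lies, most likely again reported as a bound, with an expected step of a number no higher from compound 1 to compound 4 (the limit leaves the size open). Compound 4 is thus estimated at 50000 nM, with a range from 20000 nM to 120000 nM.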

Compound 4, half-maximal inhibitory concentration: > 50000 nM
Compound 4 gave a limit, no number (the forecaster's own chance of this, stated with the estimate: 70%); the middle value lies on the limit itself.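

In this assay, among these compounds, compound 4 gives only a limit, and compound 1 does too, so no step between these two compounds can be read: the limit of > 50000 nM in this assay, at which 3 of the 4 values shown sit. The compounds shown leave open whether pyrrolidin-1-yl in place of morpholin-4-yl on the carbonyl carbon changes inhibition at all.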